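A few compounds are considered here, and "the series" means these few. Any claim that something is new, unique, unknown or untested is made for them only; others in the source may bear on it.

Working notes on the series built on the shared core of compound 1 `OC1CN(CCCSc2ccccc2)CCc2cc(OCc3ccccc3)ccc21`. Among the measured compounds shown here, in an assay for displacement of a labelled ligand from Sigma non-opioid intracellular receptor 1 (Cavia porcellus), read by scintillation counting, with a stated time of 180 min (a lower number here means a stronger inhibitor, a higher number a weaker inhibitor), compound 1 gives 376 nM, the highest number of the three measured so far; compound 2 `OC1CN(C2CCC3(CC2)OCCO3)CCc2cc(OCc3ccccc3)ccc21` gives 183 nM and compound 3 `OC1CN(C2COC(c3ccccc3)OC2)CCc2cc(OCc3ccccc3)ccc21` gives 186 nM. For the measured compounds named here, the only single-point step recorded, a 2.1-fold lower number from compound 1 to compound 2 (0.31 log units; beyond the scatter), exchanges the whole group on the amine nitrogen itself rather than a chain end. Compound 4 `O=C(CCCN1CCc2cc(OCc3ccccc3)ccc2C(O)C1)c1ccc(F)cc1` differs from compound 1 by (4-fluorophenyl)carbonyl in place of phenylsulfanyl on a saturated chain carbon, three bonds along the chain from an amine nitrogen in a ring. Going by the values given here, no measured step covers this exchange directly; the step to compound 2 shows only that alterations in this region move the number modestly. A modest decrease in the number is therefore expected, a 1.9-fold lower number from compound 1 to compound 4 (0.27 log units; within the scatter), with the direction uncertain. Compound 4 is estimated at 200 nM, within 60 nM to 650 nM.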

Compound 4, inhibition constant: 293 nM
The estimate for compound 4 lay 1.5-fold (0.17 log units) below the measured number; the measured number falls inside the stated range.
By their numbers in this assay, from the lowest: compounds 2, 3, 4 and 1 (each within the scatter of the next, the first and the last beyond it).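

On a saturated chain carbon, three bonds along the chain from an amine nitrogen in a ring, (4-fluorophenyl)carbonyl in place of phenylsulfanyl gives a 1.3-fold lower number from compound 1 to compound 4 (0.11 log units; within the scatter) in this assay and so separates the two groups by no more than the scatter. The position therefore accepts a carbonyl-linked fluorinated aryl group as well as a sulfur-linked phenyl, with no measurable difference in this assay. The data offer no explanation for this result.

The separate contributions of the carbonyl and the fluorine remain open, as phenylcarbonyl is not among the compounds shown. So does the outcome with a longer chain or a terminal amine at this position.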